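Methyl on the Ring Nitrogen: From Compound 1 to Compound 3

The source may report more compounds than this note shows. Statements on the series, on what has been measured and on what is new or still open speak of the compounds shown alone.

Compound 1 `O=C(Nc1ccc(Oc2ccnc3[nH]ccc23)cc1)c1cc2cccnc2n(-c2ccc(C(F)(F)F)cc2Cl)c1=O` was tested in a functional assay on HT-29 cells (Homo sapiens) for antiproliferative activity, read by MTT assay, with a stated time of 72 h (a lower number here means a stronger inhibitor, a higher number a weaker inhibitor), where compound 1 gives 2160 nM. Within the data shown here, its only measured neighbour is compound 2 `O=C(Nc1ccc(Oc2ccnc3[nH]ccc23)c(F)c1)c1cc2cccnc2n(-c2ccc(C(F)(F)F)cc2Cl)c1=O`, which carries fluoro in place of hydrogen on an aromatic carbon; in this assay compound 2 gives 1360 nM, and the step of a 1.6-fold lower number from compound 1 to compound 2 (0.20 log units; within the scatter) lies within the scatter. Compound 3 `Cn1ccc2c(Oc3ccc(NC(=O)c4cc5cccnc5n(-c5ccc(C(F)(F)F)cc5Cl)c4=O)cc3)ccnc21` differs from compound 1 in another place: methyl in place of hydrogen on an aromatic nitrogen. Among the measured compounds shown here, no measured step touches this aromatic nitrogen, and the single step known, from compound 1 to compound 2, concerns a different part of the shared core and is itself within the scatter. The data therefore give no direction for the change, and any expectation rests on the methyl entering alone. Compound 3 is expected to reach about 4500 nM, with a range from 1500 nM to 15000 nM, which would mean an estimated step of a 2.1-fold higher number from compound 1 to compound 3 (0.32 log units; beyond the scatter).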

Compound 3, half-maximal inhibitory concentration: 6050 nM
The estimate for compound 3 lay 1.3-fold (0.13 log units) below the measured number; the range from low to high includes it.
By their numbers in this assay, from the lowest: compounds 2 and 1 (each within the scatter of the next); then compound 3.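

In this assay, among these compounds, the aromatic nitrogen of the five-membered aromatic ring is the first place in this short series where a single change carries the number beyond the scatter (a 2.8-fold higher number from compound 1 to compound 3 (0.45 log units; beyond the scatter)). Among the compounds shown here, the only earlier step (a 1.6-fold lower number from compound 1 to compound 2 (0.20 log units; within the scatter)) stayed within the scatter and concerned another part of the shared core, so it said nothing about this position. Methyl in place of hydrogen on this nitrogen therefore gives a modestly weaker inhibitor, and no supporting measurement is available to explain the shift.

As far as these compounds go, one methyl group gives no trend, so it remains open whether an ethyl group, or a longer chain ending in an amine, on this nitrogen would raise the number further or bring it back. From the compounds shown here alone, it is also open whether the step with methyl would keep its size on the core of compound 2, which carries the fluoro.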